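Moving the methyl on the saturated-ring aryl of compound 1

The source may hold more compounds than are shown below. What is called first, only, known or untested is meant among the compounds shown, and "the series" means these compounds.

Within the data shown here, compound 1 `Cc1ccc(C2CC(c3ccccc3)=NN2c2ccc(S(N)(=O)=O)cc2)cc1` is one of two compounds measured in an ADME assay on Vero 76 cells (Chlorocebus sabaeus) for cytotoxicity, read by MTT assay, with a stated time of 96 h; a lower number here means that less compound is tolerated, a higher number that more compound is tolerated. Among the measured compounds shown here, compound 1 gives 20000 nM, the lower of the two numbers; its only neighbour is compound 2 `Cc1ccc(C2CC(c3ccc(OCc4ccccc4)cc3)=NN2c2ccc(S(N)(=O)=O)cc2)cc1`, which in this assay gives 100000 nM. For the measured compounds named here, the one step between them, a 5.0-fold higher number from compound 1 to compound 2 (0.70 log units; beyond the scatter), concerns a different part of the shared core.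

Compound 3 `Cc1ccccc1C1CC(c2ccccc2)=NN1c1ccc(S(N)(=O)=O)cc1` differs from compound 1 in this way: 2-methylphenyl in place of 4-methylphenyl on a saturated ring carbon. The change sits on a saturated ring carbon of a five-membered non-aromatic ring with 2 nitrogen. Going by the values given here, no measured step touches that position or that group, so the only comparison, a 5.0-fold higher number from compound 1 to compound 2 (0.70 log units; beyond the scatter), bears on it indirectly at most. With the same atoms joined differently and nothing gained or lost, a step in this assay within the scatter is expected, with no change at the digits printed from compound 1 to compound 3 (within the scatter). Compound 3 is therefore estimated at 20000 nM in this assay, between 8000 nM and 50000 nM.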

Compound 3, half-maximal cytotoxic concentration: 24000 nM
Compound 3: middle estimate off by 1.2-fold (0.08 log units), on the low side; measured number inside the range.
By their numbers in this assay, from the lowest: compounds 1 and 3 (each within the scatter of the next); then compound 2.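

In this assay, among these compounds, replacing 4-methylphenyl with 2-methylphenyl on a saturated ring carbon gives a 1.2-fold higher number from compound 1 to compound 3 (0.08 log units; within the scatter), the first reading at this position. This shows that, between these two compounds, relocating the methyl on this aryl ring has no effect that can be told from the scatter. Among the compounds shown here, the only step beyond the scatter remains a 5.0-fold higher number from compound 1 to compound 2 (0.70 log units; beyond the scatter), at a different part of the shared core, and nothing measured here offers an explanation for either result.

The compounds shown leave open whether 3-methylphenyl would read like these two isomers, or whether an amine or a carboxylic acid on this aryl ring would shift the number. They also leave open whether 2-methylphenyl would behave the same way alongside the benzyloxy group of compound 2.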